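A few compounds are considered here, and "the series" means these few. Any claim that something is new, unique, unknown or untested is made for them only; others in the source may bear on it.

Compound 1 `N#CC1=C(N)Oc2c(c3nc4ccccc4nc3c3ccccc23)C12C(=O)N(Cc1cnnn1-c1ccc([N+](=O)[O-])cc1)c1ccccc12` and compound 2 `Cc1ccc(-n2nncc2CN2C(=O)C3(C(C#N)=C(N)Oc4c3c3nc5ccccc5nc3c3ccccc43)c3ccccc32)cc1C` share one core and differ in a single group. In a functional assay on MCF7 cells (Homo sapiens) for antiproliferative activity, read by MTT assay, with a stated time of 48 h (on this read-out lower numbers stand for stronger inhibition and higher numbers for weaker inhibition), compound 1 gives only a limit of the assay, > 50000 nM. Compound 2 likewise gives only a limit in this assay, > 50000 nM. The change between them, (3,4-dimethylphenyl in place of 4-nitrophenyl on an aromatic nitrogen), therefore shows a step that the two limits leave unreadable from compound 1 to compound 2. Compound 3 `N#CC1=C(N)Oc2c(N)cc3nc4ccccc4nc3c2C12C(=O)N(Cc1cnnn1-c1ccc([N+](=O)[O-])cc1)c1ccccc12` carries a different core; how its core differs from that of compound 1 is not broken down here. Compound 3 too gives only a limit in this assay, > 50000 nM. Compound 4 `Cc1ccc(-n2nncc2CN2C(=O)C3(C(C#N)=C(N)Oc4c(N)cc5nc6ccccc6nc5c43)c3ccccc32)cc1C` has not been measured and differs from compound 3 by the same change, (3,4-dimethylphenyl in place of 4-nitrophenyl on an aromatic nitrogen). The step from compound 3 to compound 4 is expected to be a step that the limit leaves unreadable from compound 3 to compound 4, because the limit of > 50000 nM in this assay, at which 3 of the 3 values shown sit, and because a step that the two limits leave unreadable from compound 1 to compound 2 left nothing readable. Compound 4 is therefore expected to give about 60000 nM, most likely again only a limit, within 25000 nM to 150000 nM.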

Compound 4, half-maximal inhibitory concentration: > 50000 nM
Compound 4: a limit, no number; the forecaster's own chance of this, stated with the estimate: 85%; the middle value lies beyond the limit too.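

The step between compound 3 and compound 4 cannot be read, and neither can any other step here, as each value is only a limit: the limit of > 50000 nM in this assay, at which 4 of the 4 values shown sit. As far as these compounds go, whether 3,4-dimethylphenyl in place of 4-nitrophenyl, or a change of core, alters activity in this assay stays open.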